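Thiophene Returns to the Methylthio Analogue

The source may report more compounds than this note shows. Statements on the series, on what has been measured and on what is new or still open speak of the compounds shown alone.

Measured so far in a functional assay on HCT-116 cells (Homo sapiens), read by MTT assay, with a stated time of 72 h; a lower number here means a stronger inhibitor, a higher number a weaker inhibitor:
- compound 1 `COc1ncnc2c1c(-c1cccs1)cn2[C@@H]1O[C@H](CO)[C@@H](O)[C@H]1O` gives 440 nM
- compound 2 `CNc1ncnc2c1c(-c1cccs1)cn2[C@@H]1O[C@H](CO)[C@@H](O)[C@H]1O` gives > 20000 nM
- compound 3 `CSc1ncnc2c1c(-c1ccccc1)cn2[C@@H]1O[C@H](CO)[C@@H](O)[C@H]1O` gives > 20000 nM

For compound 3 only a limit of the assay is known, (the limit of > 20000 nM in this assay, at which 2 of the 3 values shown sit). The step to compound 4 `CSc1ncnc2c1c(-c1cccs1)cn2[C@@H]1O[C@H](CO)[C@@H](O)[C@H]1O` is thiophen-2-yl in place of phenyl on an aromatic carbon. Within the data shown here, no measured step touches this change; the only measured step, an at least 45-fold higher number from compound 1 to compound 2 (1.65 log units; beyond the scatter), concerns a different group. Compound 1, which carries the thiophen-2-yl group, shows a numerical value, whereas compound 3 sits at the limit, but these two differ in two places. An improvement for compound 4 is therefore expected but uncertain: its step of an at least 4.0-fold lower number from compound 3 to compound 4 (0.60 log units; beyond the scatter) is an estimate, and the expected value for compound 4 is 5000 nM, between 800 nM and 20000 nM.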

Compound 4, half-maximal inhibitory concentration: > 20000 nM
Compound 4 gave a limit, no number; the forecaster's own chance of this, stated with the estimate: 40%; at least 4.0-fold (0.60 log units) between middle value and limit.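

Thiophen-2-yl in place of phenyl does not by itself bring a number back in this assay: compound 4 also stands at a limit, so its steps from compound 3 and compound 2 cannot be read. With thiophen-2-yl kept, methylsulfanyl in place of methoxy gives an at least 45-fold higher number from compound 1 to compound 4 (1.65 log units; beyond the scatter). Only compound 1 has a number, and the others share one limit: the limit of > 20000 nM in this assay, at which 3 of the 4 values shown sit.

Still open, on these data alone, is whether phenyl keeps a measurable number when paired with methoxy. Also open, as far as these compounds go, is whether ethoxy or a hydroxyl group in place of methoxy would do so with thiophen-2-yl.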